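Sulfonyl aryl exchange from compound 3 to compound 4

The source may hold more compounds than are shown below. What is called first, only, known or untested is meant among the compounds shown, and "the series" means these compounds.

Of the compounds shown here, three have been measured so far in a functional assay on MCF7 cells (Homo sapiens) for antiproliferative activity, read by MTT assay, with a stated time of 24 h; a lower number here means a stronger inhibitor, a higher number a weaker inhibitor. Compound 1 (`FC(F)(F)c1ccc(-c2nn(-c3ccccc3)cc2-c2nc3ccccc3[nH]2)cc1`), which has no sulfonyl group and also differs elsewhere, gives 6330 nM. Compound 2 (`Cc1ccc(-c2nn(-c3ccccc3)cc2-c2nc3ccccc3n2S(=O)(=O)c2ccccc2)cc1`) gives 830 nM, and compound 3 (`Cc1ccc(-c2nn(-c3ccccc3)cc2-c2nc3ccccc3n2S(=O)(=O)c2cc(C)ccc2C)cc1`) gives 510 nM. Compound 3 therefore stands level with compound 2 within the scatter, while the number for compound 1 is clearly higher than both.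

The next structure, compound 4 (`Cc1ccc(-c2nn(-c3ccccc3)cc2-c2nc3ccccc3n2S(=O)(=O)c2ccc(C(F)(F)F)cc2)cc1`), carries 4-(trifluoromethyl)phenyl in place of 2,5-dimethylphenyl on a sulfonyl sulfur. Going by the values given here, only one measured step bears on this change, a 1.6-fold lower number from compound 2 to compound 3 (0.21 log units; within the scatter), which is also an exchange of the group on the sulfonyl sulfur. Among the compounds with values here, that single step stays within the scatter, and no measured compound carries 4-(trifluoromethyl)phenyl at this place, so the data favour no direction. No step beyond the scatter is expected in this assay. The estimated step is a 1.2-fold higher number from compound 3 to compound 4 (0.07 log units; within the scatter). The expected value for compound 4 is 600 nM, with an estimated range of 250 nM to 1500 nM.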

Compound 4, half-maximal inhibitory concentration: 2340 nM
Beside the measured number, compound 4's estimate is 3.9-fold (0.59 log units) below it, and the stated range ends below it.
By their numbers in this assay, from the lowest: compounds 3 and 2 (each within the scatter of the next); then compound 4; then compound 1.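

In this assay, the aryl group on the sulfonyl sulfur now makes a difference beyond the scatter: the exchange of 2,5-dimethylphenyl for 4-(trifluoromethyl)phenyl gives a 4.6-fold higher number from compound 3 to compound 4 (0.66 log units; beyond the scatter), whereas the earlier exchange at this place stayed within it. The plain phenyl of compound 2 leads to the same reading, as trifluoromethyl in place of hydrogen on an aromatic carbon gives a 2.8-fold higher number from compound 2 to compound 4 (0.45 log units; beyond the scatter), so the higher number of compound 4 holds against both other sulfonyl compounds and this place is not indifferent to the group it carries. No measurement shown here accounts for these steps.

Going by these compounds alone, with only three aryl groups on the sulfonyl sulfur, the series cannot say whether the higher number belongs to trifluoromethyl as such or would also appear with another group in its place, such as a methoxy group or a chlorine atom. As far as these compounds go, it also remains open how this position would respond to an aryl group bearing an amine or a carboxylic acid, or to a simple alkyl chain on the sulfonyl sulfur in place of the aryl group.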